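The source may report more compounds than this note shows. Statements on the series, on what has been measured and on what is new or still open speak of the compounds shown alone.

Three measured compounds share one core and differ in the chain attached to the ring oxygen and in the halogen on the aryl ring. Compound 1 `CCCCCCCCCOC1(c2ccc(Cl)cc2)SC=C(C)n2c1noc2=O` carries a nine-carbon chain and a chlorine; in a functional assay (Cavia porcellus) with Rattus norvegicus as the target (on this read-out lower numbers stand for an effect already at smaller amounts and higher numbers for an effect only at larger amounts of compound), compound 1 gives 790 nM. Compound 3 `CCCCCCCCCCCCOC1(c2ccc(Cl)cc2)SC=C(C)n2c1noc2=O` keeps the chlorine but carries the longer chain; in this assay compound 3 gives 870 nM. The change from compound 1 to compound 3 is propyl in place of hydrogen on a saturated chain carbon, nine bonds along the chain from an oxygen on a saturated carbon, and it made a step of a 1.1-fold higher number from compound 1 to compound 3 (0.04 log units; within the scatter). Compound 2 `CCCCCCCCCO[C@@]1(c2ccc(Br)cc2)SC=C(C)n2c1noc2=O` has the nine-carbon chain with a bromine in place of the chlorine; in this assay compound 2 gives 350 nM, the lowest of the three numbers, and its steps to compound 1 and to compound 3 both lie beyond the scatter. How the core of compound 2 differs from the core of compound 1 is not broken down here.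

Compound 4 `CCCCCCCCCCCCO[C@@]1(c2ccc(Br)cc2)SC=C(C)n2c1noc2=O` has not yet been measured. It differs from compound 2 by propyl in place of hydrogen on a saturated chain carbon, nine bonds along the chain from an oxygen on a saturated carbon, the same change that separates compound 1 from compound 3, at the same place. Because that change gave a 1.1-fold higher number from compound 1 to compound 3 (0.04 log units; within the scatter) in the chlorine pair, the expectation is that it will again leave the number nearly unchanged, so from compound 2 to compound 4 a step of about a 1.1-fold higher number from compound 2 to compound 4 (0.04 log units; within the scatter) is expected. Compound 4 is therefore estimated at 380 nM, expected to fall between 190 nM and 760 nM.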

Compound 4, half-maximal effective concentration: 130 nM
Compound 4: middle estimate off by 2.9-fold (0.47 log units), on the high side, and the stated range ends above it.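

In this assay, replacing hydrogen with propyl on the bromine-bearing core gave a 2.7-fold lower number from compound 2 to compound 4 (0.43 log units; beyond the scatter), so this lengthening of the chain changed the number by more than the usual scatter. Set beside the chlorine-bearing pair, the change did not carry over unchanged from one core to the other: the same change on two cores in this assay, a 1.1-fold higher number (0.04 log units; within the scatter) from compound 1 to compound 3 and a 2.7-fold lower number (0.43 log units; beyond the scatter) from compound 2 to compound 4, 3.0-fold (0.47 log units) apart, beyond the scatter of two such steps

Among these compounds, this shows that, in this series, a step read on one core was a poor guide to the same change on the other, although each core offers only a single pair of compounds. It does not show which difference between the cores matters: a bromine in place of the chlorine is one visible difference, but the core differences are not broken down here, and the data cannot assign the gap to any one feature or explain how it arises.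

On these data alone, it remains open whether a shorter chain, a longer chain or a chain carrying an amine would follow the pattern of the chlorine pair or that of the bromine pair. As far as these compounds go, it is equally open how the same propyl change would behave on a core with a fluorine or an iodine in place of the chlorine or bromine.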